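A few compounds are considered here, and "the series" means these few. Any claim that something is new, unique, unknown or untested is made for them only; others in the source may bear on it.

Measured compounds in an assay on a protein complex for binding affinity to Neuronal acetylcholine receptor; alpha4/beta2 (Rattus norvegicus); a lower number here means a stronger inhibitor, a higher number a weaker inhibitor:
compound 1 `C=Cc1cncc(O[C@@H]2CCNC2)c1` — 883 nM
compound 2 `C=Cc1cc(O[C@@H]2CCNC2)cnc1Cl` — 140 nM

Compound 1 is the weaker of the two: it gives the highest number of the pair, with compound 2 giving 140 nM after the step of a 6.3-fold lower number from compound 1 to compound 2 (0.80 log units; beyond the scatter). Among the compounds with values here, that step, chloro in place of hydrogen on an aromatic carbon, is the only measured step and it touches a different position than the change considered here.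

Compound 3 `c1cc(-c2cncc(O[C@@H]3CCNC3)c2)ccn1` is not yet measured. It differs from compound 1 by pyridin-4-yl in place of vinyl on an aromatic carbon of the shared core, two atoms from the ring nitrogen.

Within the data shown here, no measured step replaces the vinyl group, so the step from compound 1 to compound 2 bears on the present change only indirectly, showing that the core tolerates alteration without loss. A replacement of the vinyl group by a six-membered aromatic ring is a larger change than chloro for hydrogen, and its direction in this assay is not settled by the data. The working expectation is a modest lowering of the number, with the range kept wide: compound 3 is expected to give 300 nM (60 nM to 1500 nM), a step of a 2.9-fold lower number from compound 1 to compound 3 (0.47 log units; beyond the scatter) from compound 1.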

Compound 3, half-maximal inhibitory concentration: 571 nM
For compound 3 the middle estimate is 1.9-fold (0.28 log units) below the measured one; measured number inside the range.
By their numbers in this assay, from the lowest: compound 2; then compounds 3 and 1 (each within the scatter of the next).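

In this assay, this position now has a measured change: a 1.5-fold lower number from compound 1 to compound 3 (0.19 log units; within the scatter), so pyridin-4-yl and vinyl cannot be told apart here, even though the entering group has 6 heavy atoms against 2 and brings a six-membered aromatic ring and a hydrogen-bond acceptor. Within the data shown here, the place two atoms from the ring nitrogen therefore takes this much larger group with no step beyond the scatter, whereas the one such step so far remains chloro in place of hydrogen, a 6.3-fold lower number from compound 1 to compound 2 (0.80 log units; beyond the scatter). Nothing at hand bears on the origin of this result.

The compounds shown do not tell whether the nitrogen of the entering ring matters at this place, a question that a phenyl or pyridin-3-yl group there would address, nor how a saturated ring such as piperidinyl or a longer chain such as propyl would read. They also leave open whether the step seen with chloro carries over when pyridin-4-yl stands in place of vinyl.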